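The source may hold more compounds than are shown below. What is called first, only, known or untested is meant among the compounds shown, and "the series" means these compounds.

Working notes on the series. Compound 1 `Oc1cccc(-c2cc(-c3ccccc3)cc(-c3ccsc3)n2)c1` and compound 2 `Oc1cccc(-c2cc(-c3ccccc3)nc(-c3ccccc3)c2)c1` share a core that carries a 3-hydroxyphenyl group, a phenyl group and a third aryl group, arranged differently in the two. In an assay on isolated protein for inhibition of DNA topoisomerase 1 (Homo sapiens), with a stated time of 30 min, tested at 100 uM (a higher number here means a stronger effect of the compound at the concentration tested, a lower number a weaker effect), compound 1 gives 75.8%, while compound 2 gives 11.5%, the lowest of the two numbers recorded and a gap to compound 1 that lies beyond the scatter. Compound 3 `Oc1cccc(-c2cc(-c3ccccc3)nc(-c3ccsc3)c2)c1` is the next member; relative to compound 2 the change is thiophen-3-yl in place of phenyl on an aromatic carbon. Among the measured compounds shown here, compound 1 also carries a thiophen-3-yl, yet it differs from compound 2 in more than one place, so the pair offers no clean step for this single change. For compound 3 a moderate rise is nevertheless expected, a number 18.5 percentage points higher from compound 2 to compound 3 (beyond the scatter), beyond the scatter but uncertain in size. Compound 3 is estimated at 30% in this assay, with a range from 5% to 65%.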

Compound 3, a percentage reported as inhibition, at one concentration (the size of the read-out at that concentration, not a potency): 6.9%
Compound 3: the middle estimate sits 23.1 percentage points above what was measured; low and high end bracket the measured number.
By their numbers in this assay, from the lowest: compounds 3 and 2 (each within the scatter of the next); then compound 1.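

In this assay, thiophen-3-yl in place of phenyl on this aromatic carbon, next to the ring nitrogen, gives a number 4.6 percentage points lower from compound 2 to compound 3 (within the scatter), so this single change does not separate the two compounds. At this place, neither ring type gives more than a low read-out: compound 2 gives 11.5% and compound 3 gives 6.9%. No measurement at hand bears on why the step is this small.

Still open, going by these compounds, is whether a group of another kind at this place, such as an amine or a carboxylic acid, would move the number in this assay. The compounds shown also hold no one-place pair linking compound 1 to compound 2 or compound 3, so its higher number cannot be assigned to any single structural change.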